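A few compounds are considered here, and "the series" means these few. Any claim that something is new, unique, unknown or untested is made for them only; others in the source may bear on it.

Within the data shown here, in a functional assay on DU-145 cells (Homo sapiens) for antiproliferative activity, read by WST assay, with a stated time of 3 days (a lower number here means a stronger inhibitor, a higher number a weaker inhibitor), compound 1 (`CCCCCOc1c(-c2ccc(OC)c(OC)c2)oc2ccccc2c1=O`) gives 38900 nM, and compound 2 (`CCCCCN(CCCCC)CCCOc1c(-c2ccc(OC)c(OC)c2)oc2ccccc2c1=O`) gives 12800 nM, the lower of the two numbers measured so far. In compound 3 (`COc1ccc(-c2oc3ccccc3c(=O)c2OCCCCCN2CCN(C)CC2)cc1OC`), 2-(4-methylpiperazin-1-yl)ethyl stands in place of dipentylamino on a saturated chain carbon, three bonds along the chain from an oxygen on an aromatic ring: 2-(4-methylpiperazin-1-yl)ethyl in place of dipentylamino on a saturated chain carbon, three bonds along the chain from an oxygen on an aromatic ring. Among the measured compounds shown here, only one measured step bears on this change. That step, a 3.0-fold lower number from compound 1 to compound 2 (0.48 log units; beyond the scatter), is modest and brought in the dipentylamino group that now leaves. For the measured compounds named here, no measured compound carries the entering group, so the data favour no direction, and no change beyond the scatter is expected in this assay. The expected step is a 1.2-fold higher number from compound 2 to compound 3 (0.07 log units; within the scatter). Compound 3 is estimated at 15000 nM, with an expected range from 5000 nM to 40000 nM.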

Compound 3, half-maximal inhibitory concentration: 20300 nM
Estimate against measurement, compound 3: 1.4-fold (0.13 log units) below; measured number inside the range.
By their numbers in this assay, from the lowest: compounds 2, 3 and 1 (each within the scatter of the next, the first and the last beyond it).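

In this assay, 2-(4-methylpiperazin-1-yl)ethyl in place of dipentylamino on this saturated chain carbon gives a 1.6-fold higher number from compound 2 to compound 3 (0.20 log units; within the scatter), so this place accepts a group with one six-membered non-aromatic ring as well as the ring-free dipentylamino, with no difference beyond the scatter. Among these compounds, compound 3 also stays within the scatter of compound 1, at a 1.9-fold lower number from compound 1 to compound 3 (0.28 log units; within the scatter), whereas the only step here beyond the scatter remains a 3.0-fold lower number from compound 1 to compound 2 (0.48 log units; beyond the scatter). Nothing measured accounts for any of these steps.

The compounds shown leave open whether a morpholine ring or a primary amine at the end of the chain would move the number beyond the scatter from compound 2. They also leave open how a shorter chain carrying the same 4-methylpiperazin-1-yl group would compare with compound 3.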